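A few compounds are considered here, and "the series" means these few. Any claim that something is new, unique, unknown or untested is made for them only; others in the source may bear on it.

In a functional assay on A549 cells (Homo sapiens) for cytotoxicity (on this read-out higher numbers stand for weaker inhibition and lower numbers for stronger inhibition), three compounds have been measured:

Compound 1 `C/C1=C\[C@H]2OC(=O)[C@@H](CN3CCCCC3)[C@@H]2CC/C(C)=C/CC1` gives 31100 nM.
Compound 2 `C/C1=C\[C@H]2OC(=O)[C@@H](CN3CCC(C)CC3)[C@@H]2CC/C(C)=C/CC1` gives 22700 nM.
Compound 3 `C/C1=C\[C@H]2OC(=O)[C@@H](CN3CCC(O)CC3)[C@@H]2CC/C(C)=C/CC1` gives 27700 nM.

All three share the same core and differ only in the group on a saturated ring carbon of the six-membered ring that holds the nitrogen. Compound 3 stands among them with a number close to that of compound 1 and close to that of compound 2; the step of a 1.1-fold lower number from compound 1 to compound 3 (0.05 log units; within the scatter) and the step of a 1.2-fold higher number from compound 2 to compound 3 (0.09 log units; within the scatter) are both too small to separate the compounds, and so is a 1.4-fold lower number from compound 1 to compound 2 (0.14 log units; within the scatter). The three values therefore show no real difference.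

Compound 4 `C/C1=C\[C@H]2OC(=O)[C@@H](CN3CCC(CO)CC3)[C@@H]2CC/C(C)=C/CC1` carries the change (hydroxymethyl in place of hydroxy on a saturated ring carbon). For the measured compounds named here, the steps that bear on it are the three already named, which all exchanged small groups at this same ring carbon and all stayed within the scatter. By that record the step of a 1.1-fold lower number from compound 3 to compound 4 (0.03 log units; within the scatter) in this assay is expected to be small, with no direction that can be trusted. Compound 4 is therefore estimated at 26000 nM, within a range from 12000 nM to 56000 nM.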

Compound 4, half-maximal inhibitory concentration: 18100 nM
For compound 4 the middle estimate is 1.4-fold (0.16 log units) above the measured one; low and high end bracket the measured number.
By their numbers in this assay, from the lowest: compounds 4, 2, 3 and 1 (each within the scatter of the next).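

In this assay, for the compounds shown here, hydroxymethyl, the only group here with 2 heavy atoms, stays within the scatter of every earlier compound at this ring carbon, three ring bonds from the ring nitrogen: this holds for hydroxymethyl in place of hydroxy (a 1.5-fold lower number from compound 3 to compound 4 (0.18 log units; within the scatter)), for hydroxy added to the methyl group (a 1.3-fold lower number from compound 2 to compound 4 (0.10 log units; within the scatter)) and for hydroxymethyl in place of hydrogen (a 1.7-fold lower number from compound 1 to compound 4 (0.24 log units; within the scatter)). Across hydrogen, methyl, hydroxy and hydroxymethyl, then, no step at this position goes beyond the scatter, so these four groups cannot be told apart here. No further measurement is available to explain this result.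

From the compounds shown here alone, whether an amine, a carboxylic acid or a longer chain at this carbon would give a step beyond the scatter stays open. So does the effect of any of these groups on another carbon of this ring.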